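The source may report more compounds than this note shows. Statements on the series, on what has been measured and on what is new or still open speak of the compounds shown alone.

In a functional assay on HepG2 cells (Homo sapiens) for antiproliferative activity, read by MTT assay, with a stated time of 72 h (on this read-out higher numbers stand for weaker inhibition and lower numbers for stronger inhibition), compound 2 `N#Cc1ccc(/C=N/NC(=O)Nc2ccc(Oc3ccnc4[nH]ccc34)c(F)c2)cc1` gives 850 nM, the lowest of the two numbers available. Compound 1 `O=C(N/N=C/c1ccc(F)cc1)Nc1ccc(Oc2ccnc3[nH]ccc23)c(F)c1` gives 3880 nM, while compound 3 `O=C(N/N=C/c1cccc(Cl)c1Cl)Nc1ccc(Oc2ccnc3[nH]ccc23)c(F)c1` is reported as "not active" (no number reported), with no number. Compound 4 `O=C(N/N=C/c1ccc(O)cc1)Nc1ccc(Oc2ccnc3[nH]ccc23)c(F)c1`, not yet measured, carries hydroxy in place of cyano on an aromatic carbon, turning 4-cyanophenyl into 4-hydroxyphenyl (hydroxy in place of cyano on an aromatic carbon). Among the compounds with values here, only one measured step involves this cyano group: a 4.6-fold lower number from compound 1 to compound 2 (0.66 log units; beyond the scatter), a modest gain when cyano replaced fluoro. With cyano leaving, a step of similar size in the opposite direction seems likely, towards weaker inhibition, though this rests on that single step. The expected change is a 2.9-fold higher number from compound 2 to compound 4 (0.47 log units; beyond the scatter). Compound 4 is estimated at 2500 nM, with an expected range of 800 nM to 8000 nM.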

Compound 4, half-maximal inhibitory concentration: 1950 nM
Compound 4: middle estimate off by 1.3-fold (0.11 log units), on the high side; measured number inside the range.
By their numbers in this assay, from the lowest: compound 2; then compounds 4 and 1 (each within the scatter of the next).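

In this assay a 2.3-fold higher number from compound 2 to compound 4 (0.36 log units; beyond the scatter) shows that cyano keeps the lowest number against hydroxy as well as against fluoro at this position on the ring. With a 2.0-fold lower number from compound 1 to compound 4 (0.30 log units; within the scatter) hydroxy and fluoro cannot be told apart here, so swapping one for the other gives no clear change. Nothing measured here says why cyano stands apart.

On these data alone, it stays open whether an amine or a carboxylic acid in this place would give a number lower than that of compound 2. Also open, as far as these compounds go, is how a methoxy group would compare with hydroxy.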